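Aryl sulfone variation on the shared core

The compounds below may be only part of what the source reports. "The series", "measured", "known", "first", "only" and "open" are said of these compounds alone.

Three compounds in the series have numbers in a functional assay on DU-145 cells (Homo sapiens) for inhibition, read by trypan blue exclusion, with a stated time of 72 h; on this read-out higher numbers stand for weaker inhibition and lower numbers for stronger inhibition. Compound 1 `Cn1c(=O)c(S(=O)(=O)c2ccc(Cl)cc2Cl)cc2cnc(Nc3ccc4[nH]ccc4c3)nc21` gives 1000 nM in this assay, which is the second highest of the three numbers. Compound 2 `Cn1c(=O)c(S(=O)(=O)c2ccc(F)cc2F)cc2cnc(Nc3cccc4[nH]ccc34)nc21` gives 750 nM in this assay, and the gap to compound 1 lies within the scatter, so no order between the two can be read. Compound 3 `Cn1c(=O)c(S(=O)(=O)c2ccc(F)cc2)cc2cnc(Nc3ccc4[nH]ncc4c3)nc21` gives 5000 nM in this assay, a number beyond the scatter from compound 1 and the highest of the set. No two of these compounds differ in only one place, so no single change can be tied to any of these differences.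

Compound 4 `Cn1c(=O)c(S(=O)(=O)c2ccc(F)cc2[N+](=O)[O-])cc2cnc(Nc3ccc4[nH]ccc4c3)nc21` has not yet been measured. Compared with compound 1 the difference is 4-fluoro-2-nitrophenyl in place of 2,4-dichlorophenyl on a sulfonyl sulfur. Going by the values given here, there is no measured pair in the set that makes this or a related change alone, so nothing in the numbers points in a direction. The step from compound 1 to compound 4 is expected to be small, at most near the edge of the scatter, at a 1.5-fold higher number from compound 1 to compound 4 (0.18 log units; within the scatter). Compound 4 is therefore estimated at 1500 nM in this assay, with a range from 600 nM to 4000 nM that takes in the spread seen across compound 2 and compound 3.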

Compound 4, half-maximal inhibitory concentration: 1500 nM
Compound 4: the middle estimate sits on the measured number at the digits printed; the measured number falls inside the stated range.
By their numbers in this assay, from the lowest: compounds 2, 1 and 4 (each within the scatter of the next); then compound 3.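

Going by these compounds alone, the change to 4-fluoro-2-nitrophenyl in place of 2,4-dichlorophenyl on a sulfonyl sulfur gives a 1.5-fold higher number from compound 1 to compound 4 (0.18 log units; within the scatter) in this assay, the first comparison that isolates one place. Both groups keep one six-membered aromatic ring of carbon only, and this pair shows that exchanging its substituents, with the entering group carrying hydrogen-bond acceptors and the leaving group none, does not separate the two compounds on this read-out. No measurement of any property of these two groups accompanies the result, and the numbers alone offer no explanation of it.

Every aryl group shown on the sulfonyl sulfur is a substituted phenyl ring, so it remains open how a carboxylic acid or an amine on that ring, or a cyclohexyl or a short alkyl chain in its place, would read in this assay. Within the data shown here, the higher number of compound 3 cannot be tied to its sulfonyl group or to its other differing part, as no step connecting it to the other compounds can be read.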